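The source may report more compounds than this note shows. Statements on the series, on what has been measured and on what is new or still open speak of the compounds shown alone.

Measured compounds:
compound 1 `Cc1ccc(OCC(=O)N(CCCO)Cc2cccs2)cc1` — in an assay on HEK293 cells for agonist activity at transient receptor potential cation channel subfamily M member 8 (Homo sapiens), read by fluorescence and calcium flux, with a stated time of 15 min (a higher number here means that more compound is needed for the effect, a lower number that less compound is needed), compound 1 gives 3000 nM
compound 2 `CCc1ccc(OCC(=O)N(CC)Cc2cccs2)cc1` — in this assay compound 2 gives 67 nM

Compound 1 stands at the higher of the two numbers; compound 2 sits at the lower one, and the gap between them lies beyond the scatter. Among the compounds with values here, no single-place step between measured compounds is available, so the two values show only that the series spans a wide range. Compound 3 `Cc1ccc(OCC(=O)N(Cc2cccs2)c2ccccc2)cc1` differs from compound 1 by phenyl in place of 3-hydroxypropyl on an amide-type nitrogen. Within the data shown here, with no measured step of this kind, the direction is a guess. A move toward lower numbers is expected, of the size a 7.5-fold lower number from compound 1 to compound 3 (0.88 log units; beyond the scatter). Compound 3 is estimated at 400 nM in this assay, within 80 nM to 2000 nM.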

Compound 3, half-maximal effective concentration: 23 nM
Estimate against measurement, compound 3: 17-fold (1.24 log units) above, outside the stated range (below it).
By their numbers in this assay, from the lowest: compound 3; then compound 2; then compound 1.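

Within the data shown here, at the amide-type nitrogen, phenyl in place of 3-hydroxypropyl gives a 130-fold lower number from compound 1 to compound 3 (2.12 log units; beyond the scatter) in this assay, the first single-place step. This position therefore responds strongly to its substituent, and a low number here does not require the hydroxyl group. No available measurement explains this step.

The step cannot separate the loss of the hydroxyl from the gain of the ring. A plain propyl chain, a 3-methoxypropyl group or a benzyl group at this nitrogen would help to tell these apart.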